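This account rests on a few compounds, and the source may have more. Where it says the series, first, only, none or still open, it means among the compounds named here.

Compound 1 `COc1ccc(CNC(=O)/C(C#N)=C/c2ccc[nH]2)cc1` and compound 2 `COc1ccc(CNC(=O)/C(C#N)=C/c2ccoc2)cc1` share the same core and differ only in the ring attached to the double-bonded chain carbon. In a functional assay on A-431 cells (Homo sapiens) for inhibition, read by MTT assay, with a stated time of 72 h (a lower number here means a stronger inhibitor of growth, a higher number a weaker inhibitor of growth), compound 1 gives only a limit, > 50000 nM, which is not a number. In this assay, for the measured compounds named here, compound 2 gives 5000 nM, the only number among the two values shown. The other value shown, that of compound 1, is a limit (the limit of > 50000 nM in this assay, at which 1 of the 2 values shown sits). The step of an at least 10-fold lower number from compound 1 to compound 2 (1.00 log units; beyond the scatter) is therefore at least modest and beyond the scatter.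

Compound 3 `COc1ccc(CNC(=O)/C(C#N)=C/c2ccc(Cl)cc2)cc1` differs from compound 2 by 4-chlorophenyl in place of furan-3-yl on a double-bonded chain carbon bound to a double-bonded chain carbon. Going by the values given here, only the single measured step from compound 1 to compound 2 bears on this change, and it concerns a different ring swap, so it gives little direct guidance. The change from compound 2 to compound 3 is expected to shift this assay by a 2.0-fold lower number from compound 2 to compound 3 (0.30 log units; within the scatter), a small step, toward a lower number. Compound 3 is therefore estimated at 2500 nM, within a range from 500 nM to 15000 nM.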

Compound 3, concentration for 50% growth inhibition: 6000 nM
The estimate for compound 3 lay 2.4-fold (0.38 log units) below the measured number; low and high end bracket the measured number.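

In this assay, putting 4-chlorophenyl in place of furan-3-yl on this double-bonded chain carbon gives a 1.2-fold higher number from compound 2 to compound 3 (0.08 log units; within the scatter), so at this level of growth inhibition a six-membered aromatic ring of carbon only does the same as a five-membered aromatic ring with 1 hetero atom. Against 1H-pyrrol-2-yl, the second ring also stands apart, with an at least 8.3-fold lower number from compound 1 to compound 3 (0.92 log units; beyond the scatter), so two different rings now separate from compound 1 by a step beyond the scatter. The size of that step stays open-ended, as compound 1 gives a limit and not a number: the limit of > 50000 nM in this assay, at which 1 of the 3 values shown sits.

Still open, on these data alone, is whether the chlorine adds anything, which only a comparison with plain phenyl could tell. Also open, as far as these compounds go, is how this position responds to a ring carrying an amine or a carboxylic acid, or to a simple alkyl chain in place of a ring.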